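Trifluoromethyl in place of the fluorinated sulfur group

The compounds below may be only part of what the source reports. "The series", "measured", "known", "first", "only" and "open" are said of these compounds alone.

Among the measured compounds shown here, in a functional assay on DU-145 cells (Homo sapiens) for antiproliferative activity, read by propidium iodide staining, with a stated time of 96 h (on this read-out higher numbers stand for weaker inhibition and lower numbers for stronger inhibition), compound 1 `CC(O)(COc1ccc(S(F)(F)(F)(F)F)cc1)C(=O)Nc1ccc(S(F)(F)(F)(F)F)cc1` gives 24900 nM and compound 2 `CC(O)(COc1ccc(C#N)cc1)C(=O)Nc1ccc(S(F)(F)(F)(F)F)cc1` gives 32200 nM within the scatter of each other, so compound 1 stands level with its only measured neighbour. Compound 3 `CC(O)(COc1ccc(S(F)(F)(F)(F)F)cc1)C(=O)Nc1ccc(C(F)(F)F)cc1` differs from compound 1 by a group of 4 heavy atoms (1 carbon, 3 fluorine; no ring) in place of a group of 6 heavy atoms (5 fluorine, 1 sulfur; no ring), on an aromatic carbon on a six-membered aromatic ring of carbon only. For the measured compounds named here, the one measured step shows a 1.3-fold higher number from compound 1 to compound 2 (0.11 log units; within the scatter) on a swap at a different aromatic carbon, which is thin but sole support. The expected step is a 1.1-fold higher number from compound 1 to compound 3 (0.05 log units; within the scatter) and so none beyond the scatter in this assay on this evidence. For compound 3 the estimated value is 28000 nM with an expected range from 12000 nM to 60000 nM in this series.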

Compound 3, half-maximal inhibitory concentration: 27400 nM
Compound 3: the middle estimate sits 1.0-fold (0.01 log units) above what was measured; the range from low to high includes it.
By their numbers in this assay, from the lowest: compounds 1, 3 and 2 (each within the scatter of the next).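

At this position, on an aromatic carbon of a six-membered aromatic ring of carbon only, trifluoromethyl replaces the fluorinated sulfur group with a 1.1-fold higher number from compound 1 to compound 3 (0.04 log units; within the scatter) in this assay. Among the compounds shown here, this is the first step at this position, and it joins the step at the other aromatic carbon in staying within the scatter. No measurement on hand accounts for this result.

On these data alone, whether an amine or a carboxylic acid at this carbon would stay level remains open. So does the reading with a plain hydrogen there.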